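Swapping Cyano for Carboxy at the Assay Limit

The source may hold more compounds than are shown below. What is called first, only, known or untested is meant among the compounds shown, and "the series" means these compounds.

Of the compounds shown here, two have been tested so far. In a functional assay on MDA-MB-231 cells (Homo sapiens) for antiproliferative activity, with a stated time of 48 h (a lower number here means a stronger inhibitor, a higher number a weaker inhibitor), compound 1 (`COc1ccc(Nc2ccc(-c3ccccc3)nn2)cc1`) gives > 25000 nM, which is a limit and not an exact number. In this assay, compound 2 (`CCN(CC)c1ccc(-c2ccc(C#N)cc2)nn1`) gives > 25000 nM, which is also a limit. The record therefore holds no exact value yet, only (the limit of > 25000 nM in this assay, at which 2 of the 2 values shown sit).

The next compound keeps most of compound 2 and alters one group. Compound 3 (`CCN(CC)c1ccc(-c2ccc(C(=O)O)cc2)nn1`) carries carboxy in place of cyano on an aromatic carbon, para to a large group: carboxy in place of cyano on an aromatic carbon.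

Going by the values given here, no measured step between related compounds is available to show how large such a swap might be. Among the compounds with values here, the only guide is that both tested compounds sit at the same limit, so no clear gain in this assay is expected, and no step in either direction beyond the scatter. The estimated change is a step that the limit leaves unreadable from compound 2 to compound 3.

Compound 3 is expected to give about 30000 nM in this assay. The estimated range for compound 3 runs from 10000 nM to 90000 nM.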

Compound 3, half-maximal inhibitory concentration: > 25000 nM
Compound 3 was reported as a limit; the forecaster's own chance of this, stated with the estimate: 75%; the middle value is on the limit's open side.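

In this assay compound 3 gives > 25000 nM, which is a limit. Compound 2 also stands at a limit, so no step can be read for carboxy in place of cyano between compound 2 and compound 3. The compounds shown leave open how strong any of them is, and whether this swap changes anything: the limit of > 25000 nM in this assay, at which 3 of the 3 values shown sit.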